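This account rests on a few compounds, and the source may have more. Where it says the series, first, only, none or still open, it means among the compounds named here.

Compound 1 `CN1CCN(c2ccc(Nc3ncc4nc(Nc5ccc(F)cc5)n([C@H]5CCCNC5)c4n3)cc2)CC1`: 38 nM
Compound 2 `CC(=O)Nc1cccc(-n2c(Nc3ccc(F)cc3)nc3cnc(Nc4ccc(N5CCN(C)CC5)cc4)nc32)c1`: 10 nM

For the measured compounds named here, in a functional assay on HCC827 cells (Homo sapiens) for antiproliferative activity, read by MTT assay, with a stated time of 72 h (on this read-out higher numbers stand for weaker inhibition and lower numbers for stronger inhibition), compound 2 gives the lowest of the two numbers, and the one measured step, a 3.8-fold lower number from compound 1 to compound 2 (0.58 log units; beyond the scatter), tells how far it stands from compound 1. Compound 3 `CN1CCN(c2ccc(Nc3ncc4nc(Nc5ccc(F)cc5)n([C@@H]5CCCN(C(=O)CO)C5)c4n3)cc2)CC1` differs from compound 2 by 1-((hydroxymethyl)carbonyl)piperidin-3-yl in place of 3-acetamidophenyl on an aromatic nitrogen. This largely undoes the measured step: the group that set compound 2 apart from compound 1 leaves, and a ring like that of compound 1 returns, now bearing a hydroxymethylcarbonyl on its nitrogen. Going by the values given here, no measured step covers that acylation, so the number for compound 3 is expected to fall between the two measured values, estimated at 30 nM (range 10 nM to 90 nM). That corresponds to an expected step of a 3.0-fold higher number from compound 2 to compound 3 (0.48 log units; beyond the scatter).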

Compound 3, half-maximal inhibitory concentration: 66 nM
The estimate for compound 3 lay 2.2-fold (0.34 log units) below the measured number; the measured number falls inside the stated range.
By their numbers in this assay, from the lowest: compound 2; then compounds 1 and 3 (each within the scatter of the next).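

In this assay, replacing 3-acetamidophenyl with 1-((hydroxymethyl)carbonyl)piperidin-3-yl on the aromatic nitrogen gives (a 6.6-fold higher number from compound 2 to compound 3 (0.82 log units; beyond the scatter)), so the aromatic group keeps its lead even when the ring nitrogen is acylated. Adding hydroxymethylcarbonyl to that ring nitrogen gives (a 1.7-fold higher number from compound 1 to compound 3 (0.24 log units; within the scatter)), a difference that cannot be told apart from the scatter. No measurement shown here explains either result. On these data alone, it remains open whether a plain acetyl or a methyl on the ring nitrogen would fit this picture. As far as these compounds go, whether unsubstituted phenyl would match 3-acetamidophenyl also remains open.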